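The compounds below may be only part of what the source reports. "The series", "measured", "known", "first", "only" and "open" are said of these compounds alone.

Working notes on the series, read in a functional assay on MCF7 cells (Homo sapiens) for inhibition, read by MTT assay, with a stated time of 5 days; a higher number here means a weaker inhibitor, a lower number a stronger inhibitor. Compound 1 (`Cc1cc(Nc2nc(NCc3ccccc3F)nc3[nH]ncc23)n[nH]1`) gives 2310 nM, compound 2 (`Cc1cc(Nc2nc(NCc3ccccc3Cl)nc3[nH]ncc23)n[nH]1`) gives 4130 nM and compound 3 (`Cc1cc(Nc2nc(NCc3cccc(Cl)c3)nc3[nH]ncc23)n[nH]1`) gives 5620 nM. Compound 3 stands at the upper end of these numbers, together with compound 2. The measured steps read a 1.4-fold higher number from compound 2 to compound 3 (0.13 log units; within the scatter) and a 2.4-fold higher number from compound 1 to compound 3 (0.39 log units; beyond the scatter).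

Next in line is compound 4 (`Cc1cc(Nc2nc(NCc3ccc(F)cc3)nc3[nH]ncc23)n[nH]1`), which carries one change: 4-fluorophenyl in place of 3-chlorophenyl on a saturated chain carbon bound to a nitrogen on an aromatic ring. Going by the values given here, no measured compound has the 4-fluorophenyl group, so the nearest evidence is the set of swaps at the same place. Besides the two steps above, there is a 1.8-fold higher number from compound 1 to compound 2 (0.25 log units; within the scatter). Only one of the three goes beyond the scatter, and that one only modestly. Among the compounds with values here, a step beyond the scatter is therefore not expected in this assay, though any drift would more likely be towards a lower number, given that compound 1, the one fluoro compound measured, gives 2310 nM. The estimated step is a 1.6-fold lower number from compound 3 to compound 4 (0.21 log units; within the scatter). For compound 4 the expected value is 3500 nM, with an estimated range of 1600 nM to 7500 nM.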

Compound 4, half-maximal inhibitory concentration: 970 nM
Estimate against measurement, compound 4: 3.6-fold (0.56 log units) above; the measured number lies below the stated range.
By their numbers in this assay, from the lowest: compound 4; then compounds 1, 2 and 3 (each within the scatter of the next, the first and the last beyond it).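

In this assay the 4-fluorophenyl group stands apart from every other group measured on this saturated chain carbon bound to a nitrogen on an aromatic ring, with a 5.8-fold lower number from compound 3 to compound 4 (0.76 log units; beyond the scatter) and a 4.3-fold lower number from compound 2 to compound 4 (0.63 log units; beyond the scatter) and also a 2.4-fold lower number from compound 1 to compound 4 (0.38 log units; beyond the scatter), which makes compound 4 the strongest inhibitor of the four. Going by these compounds alone, the last of these steps shows what the earlier compounds could not: the 2-fluorophenyl and 4-fluorophenyl groups carry the same halogen and still differ beyond the scatter. Nothing measured alongside these values bears on why this change has this size.

Still open, on these data alone, is whether a 4-chlorophenyl group would track the 4-fluorophenyl group, so the step cannot yet be assigned to the fluorine or to its placing on the ring. As far as these compounds go, how an unsubstituted phenyl or a 4-methoxyphenyl group reads at this place also remains open.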